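Aryl variation on the shared core: towards compound 4

This account rests on a few compounds, and the source may have more. Where it says the series, first, only, none or still open, it means among the compounds named here.

Measured in a functional assay on K562 cells (Homo sapiens) for inhibition, read by sulforhodamine B assay, with a stated time of 48 h, tested at 10 uM; on this read-out higher numbers stand for more inhibition at the one concentration tested (going by the name of the read-out) and lower numbers for less inhibition:
compound 1 `Brc1cn2ccnc2c(-c2ccc3ncn(C4CCCCC4)c3c2)n1` gives 18%
compound 2 `c1ccc2c(-c3cn4ccnc4c(-c4ccc5ncn(C6CCCCC6)c5c4)n3)cccc2c1` gives 30.9%
compound 3 `CC(=O)c1ccc(-c2cn3ccnc3c(-c3ccc4ncn(C5CCCCC5)c4c3)n2)cc1` gives 9.6%

Compound 3 holds the lowest of the three numbers in this assay. Against compound 1 it differs by a number 8.4 percentage points lower from compound 1 to compound 3 (within the scatter), which is within the scatter; against compound 2 the gap is a number 21.3 percentage points lower from compound 2 to compound 3 (beyond the scatter), beyond the scatter, so of the three only compound 2 stands clearly apart from compound 3.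

Compound 4 `Fc1ccccc1-c1cn2ccnc2c(-c2ccc3ncn(C4CCCCC4)c3c2)n1` follows from compound 3 by the change (2-fluorophenyl in place of 4-acetylphenyl on an aromatic carbon). Among the compounds with values here, two steps bear on it. Replacing bromo by naphthalen-1-yl gave a number 12.9 percentage points higher from compound 1 to compound 2 (beyond the scatter), while replacing bromo by 4-acetylphenyl gave a number 8.4 percentage points lower from compound 1 to compound 3 (within the scatter), so the choice of aryl group on this carbon shifts the read-out by a modest amount in either direction. Within the data shown here, no measured step involves 2-fluorophenyl, so the direction for compound 4 rests on the spread of the three numbers alone.

For compound 4 in this assay the expected step from compound 3 is a number 8.4 percentage points higher from compound 3 to compound 4 (within the scatter), not beyond the scatter. Compound 4 is estimated at 18%, within 5% to 32%.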

Compound 4, a percentage reported as inhibition, at one concentration (the size of the read-out at that concentration, not a potency): 22.8%
Estimate against measurement, compound 4: 4.8 percentage points below; measured number inside the range.
By their numbers in this assay, from the lowest: compounds 3, 1, 4 and 2 (each within the scatter of the next, the first and the last beyond it).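

Working notes on the aryl position: in this assay, 2-fluorophenyl in place of 4-acetylphenyl gives a number 13.2 percentage points higher from compound 3 to compound 4 (beyond the scatter) and so shows that, on this aromatic carbon, exchanging one single-ring aryl group for another can produce a step beyond the scatter. The other two steps, a number 8.1 percentage points lower from compound 2 to compound 4 (within the scatter) and a number 4.8 percentage points higher from compound 1 to compound 4 (within the scatter), are both within the scatter, so 2-fluorophenyl cannot be told apart here from either naphthalen-1-yl or bromo. No measured evidence accounts for the step between the two phenyl groups.

Still open, on these data alone, is whether the read-out at this position would respond to an unsubstituted phenyl, or to a phenyl carrying an amine or a carboxylic acid. As far as these compounds go, the read-out comes from one concentration, so potency across the series also remains open.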